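A few compounds are considered here, and "the series" means these few. Any claim that something is new, unique, unknown or untested is made for them only; others in the source may bear on it.

Measured so far in an in vitro functional assay on HEK285-7 cells for antagonist activity at prostaglandin D2 receptor 2 (Homo sapiens), read by BRET and beta-arrestin recruitment; on this read-out lower numbers stand for stronger inhibition and higher numbers for weaker inhibition:
compound 1, `O=C(O)Cc1sc(C(c2ccc(F)cc2)c2ccc(F)cc2)nc1-c1ccnc(N2CCCC2)c1`: > 100000 nM
compound 2, `O=C(O)Cc1sc(C(c2ccccc2)c2ccc(Cl)cc2)nc1-c1ccc(Cl)cc1`: 75 nM
compound 3, `O=C(O)Cc1sc(CS(=O)(=O)c2ccc(Cl)cc2)nc1-c1ccc(Cl)cc1`: 730 nM

Compound 1 stands apart from the other two. In this assay, for the measured compounds named here, compound 1 gives only > 100000 nM, which is a limit of the assay rather than a number, so no value is known for it; it is the one compound that sits at the limit of > 100000 nM in this assay, at which 1 of the 3 values shown sits. Compound 2 gives 75 nM and compound 3 gives 730 nM in this assay, both of them numbers inside the measured range.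

The next compound, compound 4, `O=C(O)Cc1sc(C(c2ccc(F)cc2)c2ccc(F)cc2)nc1-c1ccnc(O)c1`, is compound 1 with a single change: hydroxy in place of pyrrolidin-1-yl on an aromatic carbon. The group that leaves is pyrrolidin-1-yl and the group that enters is hydroxy, next to the ring nitrogen and meta to a large group. Going by the values given here, no two measured compounds differ in just one place, so no measured step shows what such an exchange does in this assay. Since compound 1 gives only a limit, any step from it can only be read downward into the measured range, or not at all. The expectation is that compound 4 stays weak, with a real chance that it too stops at the limit. In this assay compound 4 is expected to give 50000 nM, within a range from 5000 nM to 300000 nM. The step of an at least 2.0-fold lower number from compound 1 to compound 4 (0.30 log units; that floor lies within the scatter) is expected to be small, if it shows at all.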

Compound 4, half-maximal inhibitory concentration: 890 nM
Compound 4: middle estimate off by 56-fold (1.75 log units), on the high side; the whole stated range lies above it.
By their numbers in this assay, from the lowest: compound 2; then compounds 3 and 4 (each within the scatter of the next). At a limit, above all of these: compound 1.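

In this assay, for the compounds shown here, hydroxy in place of pyrrolidin-1-yl on the aromatic carbon next to the ring nitrogen gives an at least 110-fold lower number from compound 1 to compound 4 (2.05 log units; beyond the scatter), the only step between measured compounds here, so what sits at this place on the shared core clearly matters. A single exchange moves the series from a compound without a known value to a compound with a number, as compound 4 gives 890 nM in this assay. Compound 1 gives > 100000 nM, which is a limit of the assay and not a number, so the step is a floor and its full size stays unknown: the limit of > 100000 nM in this assay, at which 1 of the 4 values shown sits.

The compounds shown leave open whether the step comes from losing pyrrolidin-1-yl or from gaining hydroxy, as this one exchange does both at once. They also leave open how a plain hydrogen, a methoxy group or a dimethylamino group at the same place would read, and whether the same exchange would act alike on a core carrying other groups elsewhere.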